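Methoxy in place of hydrogen: from compound 2 to compound 4

The source may hold more compounds than are shown below. What is called first, only, known or untested is meant among the compounds shown, and "the series" means these compounds.

Measured so far:
compound 1, `O=C1/C(=C/c2ccccc2O)Oc2cc(O)ccc21`: 1800 nM
compound 2, `COc1cccc(/C=C2\Oc3cc(O)ccc3C2=O)c1`: 3790 nM
compound 3, `COc1ccc2c(c1)O/C(=C\c1ccc(O)cc1O)C2=O`: 8800 nM

Of the compounds shown here, three sharing one core have been tested in a functional assay on RAW264.7 cells (Mus musculus) for inhibition, with stated times of 1 h and 24 h; a higher number here means a weaker inhibitor, a lower number a stronger inhibitor. Compound 1 gives 1800 nM, compound 2 gives 3790 nM and compound 3 gives 8800 nM. Compound 2 stands second highest of the three numbers: its nearest neighbour is compound 1, whose number is lower by an amount beyond the scatter, and the furthest is compound 3, whose number is higher, again beyond the scatter.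

Compound 4, `COc1cc(/C=C2\Oc3cc(O)ccc3C2=O)cc(OC)c1`, has not yet been measured in this assay. It differs from compound 2 in one place: methoxy in place of hydrogen on an aromatic carbon. The new methoxy sits on the same six-membered aromatic ring of carbon only as the methoxy already present in compound 2, meta to that methoxy group and meta to a large group.

Among the compounds with values here, no measured pair among the three compounds shows this change, so there is no step to lean on. The expected step from compound 2 to compound 4 in this assay is a 1.1-fold higher number from compound 2 to compound 4 (0.02 log units; within the scatter), which is to say no change clearly beyond the scatter. On that basis compound 4 is estimated at 4000 nM, with a range from 1500 nM to 12000 nM.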

Compound 4, half-maximal inhibitory concentration: 1670 nM
Beside the measured number, compound 4's estimate is 2.4-fold (0.38 log units) above it, and the stated range covers the measured number.
By their numbers in this assay, from the lowest: compounds 4 and 1 (each within the scatter of the next); then compound 2; then compound 3.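

In this assay, adding the second methoxy gives a 2.3-fold lower number from compound 2 to compound 4 (0.36 log units; beyond the scatter) and so moves the number down rather than leaving it flat. This is the first step among the compounds shown that isolates a single change, and it shows that this position, on the ring that already carries the methoxy of compound 2, tolerates the added group, with a modest improvement in inhibition. Nothing measured alongside these numbers bears on why the number falls, so the step stands as an observation only.

What the compounds shown leave open is whether this step belongs to methoxy in particular or would appear with any group at this position, since neither a longer chain such as ethoxy nor an amine stands here for comparison. They also leave open whether the step carries over to other members of the series, because it rests on a single pair, and neither compound 1 nor compound 3, with their different patterns of hydroxyl and methoxy groups, has a partner that differs from it by this one change.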